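This account rests on a few compounds, and the source may have more. Where it says the series, first, only, none or still open, it means among the compounds named here.

Measured compounds in a functional assay on HT-1080 cells (Homo sapiens) for antiproliferative activity, read by sulforhodamine B assay, with a stated time of 48 h; a higher number here means a weaker inhibitor, a lower number a stronger inhibitor:

compound 1 `CC(=O)Nc1ccc(S(=O)(=O)Oc2ccccc2C(C)C)cc1` gives 12000 nM
compound 2 `CC(=O)Nc1ccc(S(=O)(=O)Oc2ccccc2I)cc1` gives 17000 nM

For the measured compounds named here, only two compounds have been measured so far, and they share the same core; they differ only at one aromatic carbon, where compound 1 carries an isopropyl group and compound 2 an iodine. The step of a 1.4-fold higher number from compound 1 to compound 2 (0.15 log units; within the scatter) is within the scatter, so the two numbers cannot be told apart with confidence, and compound 2 stands essentially level with compound 1.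

Compound 3 `CCCCCC(=O)Nc1ccc(S(=O)(=O)Oc2ccccc2I)cc1` has not yet been measured. It keeps the iodine of compound 2 and changes the other end of the molecule: butyl in place of hydrogen on a saturated chain carbon bound to a carbonyl carbon. Neither measured step touches that part of the structure, so nothing measured bears directly on this change. With no guide in the data, the expectation for compound 3 is a step of a 1.1-fold lower number from compound 2 to compound 3 (0.05 log units; within the scatter), that is, none beyond the scatter. Compound 3 is therefore estimated at 15000 nM, with a range from 5000 nM to 50000 nM.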

Compound 3, half-maximal inhibitory concentration: 9600 nM
Estimate against measurement, compound 3: 1.6-fold (0.19 log units) above, within the range that was stated.
By their numbers in this assay, from the lowest: compounds 3, 1 and 2 (each within the scatter of the next).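

For the compounds shown here, this is the first measurement at the acetamido end of the molecule, as the earlier compounds differed only at the other end. In this assay the step is a 1.8-fold lower number from compound 2 to compound 3 (0.25 log units; within the scatter), so putting butyl in place of hydrogen on this saturated chain carbon, which turns acetamido into (pentylcarbonyl)amino, gives a compound that cannot be told apart from compound 2. Adding these 4 heavy atoms at this place therefore leaves the activity level within the scatter, and no other measurement here explains that result.

Still open, on these data alone, is whether a longer chain, or an amine or a carboxylic acid at the end of the chain, would move the number beyond the scatter. Also open, as far as these compounds go, is whether the butyl change would give the same result with isopropyl in place of iodo.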